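Aryl-piperazine variation on the shared core: compound 3

A few compounds are considered here, and "the series" means these few. Any claim that something is new, unique, unknown or untested is made for them only; others in the source may bear on it.

Of the compounds shown here, two have been measured. Compound 1 `Nc1scc(CN2CCN(c3ccc(F)c(F)c3)CC2)c1C(=O)c1ccc(Cl)cc1` carries a 3,4-difluorophenyl on the ring amine nitrogen, and in a functional assay on CHO cells with adenosine receptor A1 (Homo sapiens) as the target, read by cAMP accumulation and immunoassay, with a stated time of 6 min, tested at 0.1 uM (on this read-out lower numbers stand for a stronger effect and higher numbers for a weaker effect at the one concentration tested), compound 1 gives -34%. Compound 2 `Nc1scc(CN2CCN(c3cccc(Cl)c3)CC2)c1C(=O)c1ccc(Cl)cc1` carries a 3-chlorophenyl at the same place, and in this assay compound 2 gives -20%. Among the measured compounds shown here, the single step so far, a number 14 percentage points higher from compound 1 to compound 2 (beyond the scatter), is modest but beyond the scatter, so compound 2 stands as the highest of the two numbers, that is the weaker effect at the one concentration.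

Compound 3 `Nc1scc(CN2CCN(c3ccccc3Cl)CC2)c1C(=O)c1ccc(Cl)cc1` is not yet measured. It differs from compound 2 by 2-chlorophenyl in place of 3-chlorophenyl on an amine nitrogen in a ring. For the measured compounds named here, no measured step moves the chlorine around the phenyl ring; the only step available, a number 14 percentage points higher from compound 1 to compound 2 (beyond the scatter), exchanges one substitution pattern of that phenyl for another and shows that such an exchange can move the read-out beyond the scatter. No direction for compound 3 can be read from the data; a step of the size of a number 2 percentage points higher from compound 2 to compound 3 (within the scatter) is expected, with wide uncertainty. Compound 3 is expected to give -18% in this assay, between -42% and 4%.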

Compound 3, a percentage reported as activity, at one concentration (the size of the read-out at that concentration, not a potency): 2%
Beside the measured number, compound 3's estimate is 20 percentage points below it; low and high end bracket the measured number.
By their numbers in this assay, from the lowest: compound 1; then compound 2; then compound 3.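

In this assay, the same atoms joined differently are enough to shift the read-out: moving from 3-chlorophenyl to 2-chlorophenyl gives a number 22 percentage points higher from compound 2 to compound 3 (beyond the scatter), so at this amine nitrogen in a ring, the place of the chlorine on the phenyl matters by itself, something the earlier step could not show, as it changed both the halogen and the substitution pattern. The full span now measured at this place is a number 36 percentage points higher from compound 1 to compound 3 (beyond the scatter), which leaves compound 3, with the 2-chlorophenyl, as the weakest of the three at the one concentration tested, and the order from strongest to weakest runs 3,4-difluorophenyl, 3-chlorophenyl, 2-chlorophenyl. Nothing at hand gives a reason for this shift.

The compounds shown leave open whether 4-chlorophenyl would continue this order or break it, and whether the weaker read-out belongs to chlorine in particular or would also appear with 2-fluorophenyl or 2-methoxyphenyl at the same place. On these data alone, with a single concentration behind each number, whether these differences in effect would hold at other concentrations also stays open.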